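Swapping the Acid-Bearing Ring in a Microsomal Stability Series

The source may hold more compounds than are shown below. What is called first, only, known or untested is meant among the compounds shown, and "the series" means these compounds.

Compound 3 `Cc1c(OCCCCOc2ccc(C(=O)O)cc2Cl)ccc(C(=O)CC(C)C)c1O` gives 61% in an ADME assay (liver) for metabolic stability, with Liver microsome (Rattus norvegicus) as the target, read by LC-MS, using microsomes and NADPH, with stated times of 5 min and 60 min, tested at 4 uM (a lower number here means that less of the compound is left, a higher number that more of the compound is left), the highest of the three numbers measured, though compound 1 `Cc1c(OCCCCOc2ccc(C(=O)O)cc2F)ccc(C(=O)CC(C)C)c1O` lies within the scatter of it at 57%, while compound 2 `Cc1ccc(C(=O)O)cc1OCCCCOc1ccc(C(=O)CC2CCCC2)c(O)c1C` is far lower at 9%. Among the compounds with values here, the only measured step, a number 4 percentage points higher from compound 1 to compound 3 (within the scatter), is within the scatter. Compound 4 `Cc1ccc(C(=O)O)cc1OCCCCOc1ccc(C(=O)CC(C)C)c(O)c1C` differs from compound 3 by 5-carboxy-2-methylphenyl in place of 4-carboxy-2-chlorophenyl on an oxygen on a saturated carbon. Within the data shown here, no measured step covers this change directly. Compound 2 carries the same entering group but differs elsewhere, and its low value is the only hint available. A drop beyond the scatter is therefore expected, as a number 26 percentage points lower from compound 3 to compound 4 (beyond the scatter), with wide uncertainty. Compound 4 is estimated at 35%, ranging from 10% to 60%.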

Compound 4, percent of the compound remaining: 21%
For compound 4 the middle estimate is 14 percentage points above the measured one; low and high end bracket the measured number.
By their numbers in this assay, from the lowest: compound 2; then compound 4; then compounds 1 and 3 (each within the scatter of the next).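

In this assay, 5-carboxy-2-methylphenyl in place of 4-carboxy-2-chlorophenyl gives a number 40 percentage points lower from compound 3 to compound 4 (beyond the scatter), and in place of 4-carboxy-2-fluorophenyl it gives a number 36 percentage points lower from compound 1 to compound 4 (beyond the scatter). On this oxygen, then, exchanging the whole ring counts for far more than chloro versus fluoro did. Isopropyl in place of cyclopentyl on a saturated chain carbon bound to a carbonyl carbon gives a modest step, a number 12 percentage points higher from compound 2 to compound 4 (beyond the scatter).

No measurement here gives a reason for these steps. Also open, as far as these compounds go, is which part of the ring exchange carries the loss, and a 4-carboxy-2-methylphenyl group would separate the methyl from the shifted carboxy group.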